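The source may hold more compounds than are shown below. What is called first, only, known or untested is meant among the compounds shown, and "the series" means these compounds.

Three compounds share one core and differ only in a single substituent on an aromatic carbon. Compound 2 `O[C@](Cc1ccccc1)(c1ccccc1)[C@@H]1CNCCO1` carries a hydrogen there; in an assay on isolated protein for displacement of a labelled ligand from sodium-dependent dopamine transporter (Homo sapiens), tested at 1000 nM (a lower number here means less inhibition, a higher number more inhibition at the concentration tested (going by the name of the read-out)), compound 2 gives 5.5%. Compound 1 `CCOc1ccccc1C[C@@](O)(c1ccccc1)[C@@H]1CNCCO1` gives 3.8% and compound 3 `COc1cccc(C[C@@](O)(c2ccccc2)[C@@H]2CNCCO2)c1` gives 4.3%, so compound 2 shows the highest of the three numbers, though each gap lies within the scatter. Compound 4 `O[C@](Cc1ccccc1SC(F)(F)F)(c1ccccc1)[C@@H]1CNCCO1` differs from compound 2 by (trifluoromethyl)sulfanyl in place of hydrogen on an aromatic carbon. The two comparable steps, the loss of ethoxy a number 1.7 percentage points higher from compound 1 to compound 2 (within the scatter) and the gain of methoxy a number 1.2 percentage points lower from compound 2 to compound 3 (within the scatter), both stayed within the scatter, and nothing among these compounds shows a group on an aromatic carbon shifting the read-out. The expected step of no change at the digits printed from compound 2 to compound 4 (within the scatter) is therefore none beyond the scatter. Compound 4 is estimated at 5.5%, between 0% and 15%.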

Compound 4, a percentage reported as inhibition, at one concentration (the size of the read-out at that concentration, not a potency): 6.2%
Compound 4: middle estimate off by 0.7 percentage points, on the low side; low and high end bracket the measured number.
By their numbers in this assay, from the lowest: compounds 1, 3, 2 and 4 (each within the scatter of the next).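

In this assay, putting (trifluoromethyl)sulfanyl, with its 5 heavy atoms, on this aromatic carbon gives a number 0.7 percentage points higher from compound 2 to compound 4 (within the scatter), and exchanging ethoxy for the same group gives a number 2.4 percentage points higher from compound 1 to compound 4 (within the scatter). So even this sulfur- and fluorine-bearing group, ortho to a large group, leaves the read-out unmoved, extending the flat picture beyond the smaller ether groups. No measurement among the data bears on why the number stays put. On these data alone, whether an amine or a carboxylic acid at this position would shift the read-out remains open.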